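The compounds below may be only part of what the source reports. "The series", "measured", "known", "first", "only" and "open" are said of these compounds alone.

Working notes on the series. Three measured members share the core of compound 2, `CCCNC(=O)C1CCN(C(=O)c2cc3sc(C#N)cc3n2Cc2ccc(OC)cc2)CC1`. In an ADME assay on microsomes from liver (Homo sapiens) for metabolic stability (on this read-out lower numbers stand for a shorter-lived compound and higher numbers for a longer-lived compound), compound 2 gives 0.187 h, the highest of the three numbers in hand. Compound 1, `CCCNC(=O)C1CC12CCN(C(=O)c1cc3sc(Br)nc3n1Cc1ccc(OC)cc1)CC2`, gives 0.0828 h in this assay, and compound 3, `CCCNC(=O)[C@H]1CC[C@H](NC(=O)c2cc3sc(Br)cc3n2Cc2ccc(OC)cc2)CC1`, gives 0.0662 h; both of these stand below compound 2 by more than the scatter, with compound 3 the furthest away and compound 1 the nearest.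

Next in line is compound 4, `CCCNC(=O)C1CCN(C(=O)c2cc3sc(-c4ccccc4F)cc3n2Cc2ccc(OC)cc2)CC1`. Its structure is that of compound 2 with a single change: 2-fluorophenyl in place of cyano on an aromatic carbon. For the measured compounds named here, no pair of measured compounds differs in just this one place, so nothing measured shows the size of such a step, and the expectation rests on the position of compound 2 alone. The expected step of a 1.6-fold lower number from compound 2 to compound 4 (0.19 log units; within the scatter) is small and in the downward direction, hardly beyond the scatter. Compound 4 is therefore estimated at 0.12 h, with a range from 0.05 h to 0.35 h.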

Compound 4, half-life: 0.592 h
Compound 4: the middle estimate sits 4.9-fold (0.69 log units) below what was measured; the whole stated range lies below it.
By their numbers in this assay, from the lowest: compounds 3 and 1 (each within the scatter of the next); then compound 2; then compound 4.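

For the compounds shown here, at the aromatic carbon next to the ring sulfur, the only single-place step so far runs upward in this assay: 2-fluorophenyl in place of cyano gives a 3.2-fold higher number from compound 2 to compound 4 (0.50 log units; beyond the scatter). This position therefore accepts a group of 7 heavy atoms, with a six-membered aromatic ring, in place of one of 2 heavy atoms, with no loss of half-life and a gain beyond the scatter. Nothing in hand gives a reason for this rise.

From the compounds shown here alone, whether the rise follows from the aromatic ring itself or from its fluorine remains open, and an unsubstituted phenyl at this carbon would separate the two. A small alkyl group such as methyl, or an amine, at the same place would show whether the step depends on the size of the group.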